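The compounds below may be only part of what the source reports. "The series", "measured", "known", "first", "only" and "open" are said of these compounds alone.

Compound 1, `CCCCc1ccc(S(=O)(=O)NCCCCCCNCc2ccc(Br)cc2)cc1`, is the reference point of this account. In a functional assay on MIA PaCa-2 cells (Homo sapiens) for inhibition, read by MTT assay, with a stated time of 72 h (on this read-out higher numbers stand for weaker inhibition of growth and lower numbers for stronger inhibition of growth), compound 1 gives 5700 nM, the highest of the three numbers recorded. Compound 2, `O=S(=O)(NCCCNCc1cccc(Cl)c1)c1cc(C(F)(F)F)cc(C(F)(F)F)c1`, gives 4400 nM in this assay, a value that sits within the scatter of compound 1. Compound 3, `O=S(=O)(NCCCNCC1COc2ccccc2O1)c1cc(C(F)(F)F)cc(C(F)(F)F)c1`, gives 2600 nM in this assay, which lies beyond the scatter from compound 1. Among the compounds with values here, the one step recorded between compounds that differ in a single place is a 1.7-fold lower number from compound 2 to compound 3 (0.23 log units; within the scatter), and it concerns the group on the saturated chain carbon bound to the amine nitrogen, not the aromatic sulfonyl end.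

Compound 4, `CC(C)(C)c1ccc(S(=O)(=O)NCCCCCCNCc2ccc(Br)cc2)cc1`, differs from compound 1 by tert-butyl in place of butyl on an aromatic carbon. Within the data shown here, no measured step touches this part of the molecule, so nothing in the data points to a direction. The expectation is therefore that the change from compound 1 to compound 4 stays within the scatter, no change at the digits printed from compound 1 to compound 4 (within the scatter). Compound 4 is thus estimated at 5700 nM in this assay, with a range from 2800 nM to 11500 nM.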

Compound 4, concentration for 50% growth inhibition: 2970 nM
Compound 4: the middle estimate sits 1.9-fold (0.28 log units) above what was measured; low and high end bracket the measured number.
By their numbers in this assay, from the lowest: compounds 3, 4, 2 and 1 (each within the scatter of the next, the first and the last beyond it).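

Within the data shown here, the step of a 1.9-fold lower number from compound 1 to compound 4 (0.28 log units; within the scatter) in this assay gives the first reading at this position, on an aromatic carbon para to a large group, which the earlier compounds left untouched. Compound 1 and compound 4 carry the same four carbons, joined as butyl or as tert-butyl, and this change in branching alone stays within the scatter, so the read-out does not separate the two groups here. No measurement shown bears on the reason for this result.

The compounds shown leave open how an amine, a carboxylic acid or a longer chain would read at this aromatic carbon in this assay. Among these compounds, they also leave open whether tert-butyl in place of butyl would read the same way with a different group on the amine nitrogen than the one shared by compound 1 and compound 4.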